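The compounds below may be only part of what the source reports. "The series", "measured", "known", "first", "only" and "open" are said of these compounds alone.

Working notes on the series. Compound 2 `CCCCN(CCCC)CN1C(=O)/C(=N\c2ncc(Cc3cc(OC)c(OC)c(OC)c3)c(N)n2)c2cc(Cl)ccc21` carries a dibutylamino group on the saturated chain carbon bound to the amide-type nitrogen in the ring of the shared core. In an ADME assay on CCRF-CEM cells (Homo sapiens) for cytotoxicity, read by MTT assay, with a stated time of 5 days (on this read-out higher numbers stand for lower toxicity in this test and lower numbers for higher toxicity in this test), compound 2 has "not determined" (no result reported) as its entry, with no number reported, so it cannot be placed on the numbers. Going by the values given here, the two measured members frame the range: compound 1 `COc1cc(Cc2cnc(/N=C3\C(=O)N(CN4CCC(C)CC4)c4ccc(Cl)cc43)nc2N)cc(OC)c1OC` gives 46.3 ug/mL in this assay, and compound 3 `COc1cc(Cc2cnc(/N=C3\C(=O)N(CN4CCN(c5ccc(Cl)cc5)CC4)c4ccc(Cl)cc43)nc2N)cc(OC)c1OC` gives 40.1 ug/mL in this assay; these two values lie within the usual scatter of one another, so no order between them is read.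

Compound 4 `CCN(CC)CN1C(=O)/C(=N\c2ncc(Cc3cc(OC)c(OC)c(OC)c3)c(N)n2)c2cc(Cl)ccc21` differs from compound 2 by a single change, diethylamino in place of dibutylamino on a saturated chain carbon bound to an amide-type nitrogen in a ring. Among the compounds with values here, no measured step reports what such a change does in this assay, and compound 2 itself has no number, so the step from compound 2 to compound 4 cannot be sized from the data; the expectation is for a result of the same order as compounds 1 and 3, with no direction beyond the scatter claimed. For compound 4 in this assay the estimate is 40 ug/mL, in the range 20 ug/mL to 80 ug/mL.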

Compound 4, half-maximal cytotoxic concentration: 98.4 ug/mL
The estimate for compound 4 lay 2.5-fold (0.39 log units) below the measured number, and the stated range ends below it.
By their numbers in this assay, from the lowest: compounds 3 and 1 (each within the scatter of the next); then compound 4.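

In this assay there is a 2.1-fold higher number from compound 1 to compound 4 (0.33 log units; beyond the scatter) with diethylamino in place of 4-methylpiperidin-1-yl on a saturated chain carbon bound to an amide-type nitrogen in a ring. Going by these compounds alone, compound 1 and compound 3 lie within the scatter of each other, so this is the first sign that the amine at this place can shift the read-out towards lower toxicity in this test, although the step is modest and rests on a single pair. No measured evidence on the origin of this step is at hand.

Going by these compounds, the step from dibutylamino to diethylamino cannot be read with no number for compound 2, so the role of chain length on this amine stays open. Also open, on these data alone, is whether dimethylamino or morpholin-4-yl on the same carbon would read like compound 4 or like compound 1.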